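The source may hold more compounds than are shown below. What is called first, only, known or untested is meant among the compounds shown, and "the series" means these compounds.

Measured so far in an ADME assay on MT4 cells (Homo sapiens) for cytotoxicity, read by MTT assay, with a stated time of 96 h; a lower number here means that less compound is tolerated, a higher number that more compound is tolerated:
- compound 1 `O=[N+]([O-])c1ccc(/N=N/N2CCCC2)cc1` gives >= 100000 nM, which is a limit of the assay.
- compound 2 `CN(C)CCCNc1ccc(/N=N/c2ccccc2)cc1` gives 17000 nM.
- compound 3 `c1ccc(/N=N/N2CCCC2)cc1` gives > 100000 nM, also a limit of the assay.

Compound 2 is the only one of the three with a number; the other two stand at limits. Compound 3 and compound 1 differ by nitro in place of hydrogen on an aromatic carbon, and the step that the two limits leave unreadable from compound 3 to compound 1 cannot be read, because both ends sit at limits, the limit of > 100000 nM in this assay, at which 1 of the 3 values shown sits, and (the limit of >= 100000 nM in this assay, at which 1 of the 3 values shown sits).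

Compound 4 `CN(C)CCCNc1ccc(/N=N/c2ccc([N+](=O)[O-])cc2)cc1` is not yet measured. It differs from compound 2 by nitro in place of hydrogen on an aromatic carbon. This is the same kind of change as from compound 3 to compound 1, though the surroundings differ: in compound 4 the nitro sits para to a large group, in compound 1 para to a group of 7 heavy atoms. How the core of compound 2 differs from that of compound 3 is not broken down here.

Within the data shown here, for compound 4 the step of a 1.2-fold higher number from compound 2 to compound 4 (0.07 log units; within the scatter) is expected to be small, since the one measured instance of this change, a step that the two limits leave unreadable from compound 3 to compound 1, shows no readable movement. Compound 4 is therefore estimated at 20000 nM, between 6000 nM and 60000 nM.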

Compound 4, half-maximal cytotoxic concentration: 19000 nM
Beside the measured number, compound 4's estimate is 1.1-fold (0.02 log units) above it; the measured number falls inside the stated range.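

In this assay, nitro in place of hydrogen on an aromatic carbon, para to a large group, gives a 1.1-fold higher number from compound 2 to compound 4 (0.05 log units; within the scatter), so on this core the two values cannot be told apart. The same change on the core of compound 3, leading to compound 1, cannot be read, since both ends of that step are limits of the assay and not numbers. The series therefore holds a single readable instance of this change, on a single core, and that instance does not show that the result carries from one core to another.

Still open, on these data alone, is how other groups on the same aromatic carbon, such as a carboxylic acid or trifluoromethyl, would stand against compound 2 in this assay. Also open, as far as these compounds go, is whether a longer chain in place of the chain carried by compound 2 would leave its number where it stands, with or without the nitro.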